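Hydroxy for chloro on a thiazole acetic acid antagonist

The compounds below may be only part of what the source reports. "The series", "measured", "known", "first", "only" and "open" are said of these compounds alone.

Of the compounds shown here, three have been measured in an in vitro functional assay on HEK285-7 cells for antagonist activity at prostaglandin D2 receptor 2 (Homo sapiens), read by BRET and beta-arrestin recruitment; a higher number here means a larger maximal response, a lower number a smaller maximal response. Compound 1 `O=C(O)Cc1sc(C(c2ccc(F)cc2)c2ccc(F)cc2)nc1-c1ccnc(Cl)c1` gives 80% in this assay. Compound 2 `O=C(O)Cc1sc(C(c2ccccc2)c2ccccc2)nc1-c1ccc(F)c(F)c1` gives 80% in this assay, and compound 3 `O=C(O)Cc1sc(C(c2ccccc2)c2ccc(O)cc2)nc1-c1ccc(F)cc1` gives 80% in this assay. Compound 1 thus stands level with compound 2 and compound 3 at the digits shown; the gap to either of them lies within the scatter of this kind of measurement, so no order among the three can be read from these numbers.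

On these data alone, the step that remains open leads from compound 1 to compound 4 `O=C(O)Cc1sc(C(c2ccc(F)cc2)c2ccc(F)cc2)nc1-c1ccnc(O)c1`, which has yet to be measured in this assay. The change is hydroxy in place of chloro on an aromatic carbon, placed on an aromatic carbon of a six-membered aromatic ring with one nitrogen, next to the ring nitrogen and meta to a large group; read one bond further out, it turns a 2-chloropyridin-4-yl into a 2-hydroxypyridin-4-yl.

Among the compounds with values here, no step between measured compounds is available, and the three measured compounds sit together at the same level. On that basis the author expects no change beyond the scatter, with the step from compound 1 to compound 4 estimated as a number 2 percentage points lower from compound 1 to compound 4 (within the scatter). For compound 4 the estimated value in this assay is 78%, expected between 65% and 90%.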

Compound 4, largest response reached (reported as efficacy), in percent of the reference or control that the assay uses: 60%
The estimate for compound 4 lay 18 percentage points above the measured number, outside the stated range (below it).
By their numbers in this assay, from the lowest: compound 4; then compounds 1, 2 and 3 (each within the scatter of the next).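

Exchanging chloro for hydroxy on the aromatic carbon next to the ring nitrogen changes the result in this assay and gives a number 20 percentage points lower from compound 1 to compound 4 (beyond the scatter) while the rest of the molecule stays the same. Within the data shown here, this is the first step in the set to pass beyond the scatter: the earlier compounds stood level and offered no pair differing in one place, so they could not show that the maximal response is sensitive to what this position carries. No measurement at hand bears on why the number falls with hydroxy here, so the step stands as an observation without an explanation.

On these data alone, how an amine, a methoxy group or a plain hydrogen on this carbon would compare with chloro and hydroxy remains open. So does the question of whether the same exchange would move the response by a similar amount with other groups elsewhere on the shared core.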